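Replacing a Bromophenyl Side Group with a Nitrophenyl

This account rests on a few compounds, and the source may have more. Where it says the series, first, only, none or still open, it means among the compounds named here.

Measured compounds:
Compound 1 `O=C1/C(=C\c2c(Cl)cccc2Cl)c2ccccc2N1c1c(Cl)cccc1Cl`: 50 ug/mL
Compound 2 `O=C1/C(=C\c2cccc(Br)c2)c2ccccc2N1c1c(Cl)cccc1Cl`: 2 ug/mL

In a functional assay on KB cells (Homo sapiens) for cytotoxicity, read by MTT assay, with a stated time of 72 h (on this read-out higher numbers stand for an effect only at larger amounts of compound and lower numbers for an effect already at smaller amounts), compound 1 gives 50 ug/mL, while compound 2 gives 2 ug/mL. Within the data shown here, compound 2 thus stands at the lower of the two numbers; the one measured step, a 25-fold lower number from compound 1 to compound 2 (1.40 log units; beyond the scatter), shows that changing the aryl group at this position can move the read-out strongly.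

Compound 3 `O=C1/C(=C\c2ccccc2[N+](=O)[O-])c2ccccc2N1c1c(Cl)cccc1Cl` differs from compound 2 in one place: 2-nitrophenyl in place of 3-bromophenyl on a double-bonded chain carbon bound to a double-bonded ring carbon. Among the measured compounds shown here, the only step that bears on this change is the one from compound 1 to compound 2, which was large. It tells that this position is sensitive, but the 2-nitrophenyl group differs from both aryl groups already measured, so the direction is open. Since the 3-bromophenyl of compound 2 gave the lower number and compound 1 with its 2,6-dichlorophenyl gave the higher one, a shift back toward compound 1 is expected, of a size given by a 5.0-fold higher number from compound 2 to compound 3 (0.70 log units; beyond the scatter). Compound 3 is therefore estimated at 10 ug/mL, within 2.5 ug/mL to 40 ug/mL.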

Compound 3, concentration for half-maximal effect: 1 ug/mL
For compound 3 the middle estimate is 10-fold (1.00 log units) above the measured one; measured number below the stated range.
By their numbers in this assay, from the lowest: compounds 3 and 2 (each within the scatter of the next); then compound 1.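

In this assay, the step of a 2.0-fold lower number from compound 2 to compound 3 (0.30 log units; within the scatter) lies within the usual scatter, so 2-nitrophenyl and 3-bromophenyl cannot be told apart at this place, on a double-bonded chain carbon bound to a double-bonded ring carbon, even though the entering group has different atoms and brings hydrogen-bond acceptors that 3-bromophenyl lacks. The step of a 50-fold lower number from compound 1 to compound 3 (1.70 log units; beyond the scatter) is large and beyond the scatter, so the low number seen with compound 2 is not tied to bromine: a second aryl group without bromine also stands far from the 2,6-dichlorophenyl of compound 1. Nothing at hand explains why these aryl groups read as they do.

The three compounds leave open whether the large gap to compound 1 comes from its two chlorine atoms, from where they sit on the ring, or from both, and a plain phenyl group or a 2-chlorophenyl group at this place would help to separate these readings. They also leave open how the read-out would respond to an aryl group carrying an amine or a carboxylic acid.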